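The source may report more compounds than this note shows. Statements on the series, on what has been measured and on what is new or still open speak of the compounds shown alone.

Measured so far in an assay on cells with melanin-concentrating hormone receptor 1 (Homo sapiens) as the target, read by radioligand binding; a lower number here means a stronger inhibitor, a higher number a weaker inhibitor:
- compound 1 `CC1CC1COc1cccc2ccc(N)nc12`: 1640 nM
- compound 2 `Nc1ccc2cccc(OCC3CC4CCC3C4)c2n1`: 137 nM
- compound 3 `CNc1ccc2cccc(OC(C)CC(C)(C)C)c2n1`: 310 nM

Among these three, compound 1 carries the highest number in this assay, and so is the weakest inhibitor of the set: the gap to compound 3 lies beyond the scatter, and the gap to compound 2 is wider still. Within the data shown here, compounds 2 and 3 share the core of compound 1 but differ from it in more than one place, so no single step between measured compounds can be drawn.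

The account now follows compound 1 to compound 4 `CCCC(C)Oc1cccc2ccc(N)nc12`, which is not yet measured. The change is small and confined to one place: 1-methylbutyl in place of (2-methylcyclopropyl)methyl on an oxygen on an aromatic ring. Nothing else on the core moves.

Among the measured compounds shown here, with no measured step of this kind to lean on, the expectation rests on the set as a whole. Compound 3, whose oxygen also carries a branched open chain, gives 310 nM, a markedly lower number than compound 1. The step from the ring-bearing chain to the open chain is therefore expected to lower the number, a 2.7-fold lower number from compound 1 to compound 4 (0.44 log units; beyond the scatter), a modest move beyond the scatter. Compound 4 is accordingly estimated at 600 nM, within a range from 200 nM to 1800 nM.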

Compound 4, half-maximal inhibitory concentration: 105 nM
For compound 4 the middle estimate is 5.7-fold (0.76 log units) above the measured one, outside the stated range (below it).
By their numbers in this assay, from the lowest: compounds 4 and 2 (each within the scatter of the next); then compound 3; then compound 1.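

In this assay, placing 1-methylbutyl instead of (2-methylcyclopropyl)methyl on the oxygen gives a 16-fold lower number from compound 1 to compound 4 (1.19 log units; beyond the scatter), the first single change read at this position. The step is large even though both groups have 5 heavy atoms, all carbon, and neither has hydrogen-bond donors or acceptors, so this position separates two groups that the computed counts distinguish chiefly by the three-membered ring, present in one and absent in the other. Nothing measured here explains the size of this step.

A straight pentyl chain or a cyclopentyl group on the same oxygen would help show whether the step follows from losing the ring or is particular to 1-methylbutyl. From the compounds shown here alone, it also remains open whether a longer chain, or one ending in an amine, would keep the number this low.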